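The source may hold more compounds than are shown below. What is called first, only, known or untested is meant among the compounds shown, and "the series" means these compounds.

Measured compounds:
compound 1 `C=CC[C@@H]1C[C@@H](c2ccc(Cl)c(Cl)c2)[C@H](NC(=O)c2cc(-c3c(Cl)cnn3C)c(Cl)o2)CN1` — 160 nM
compound 2 `COCC[C@@H]1C[C@@H](c2ccc(Cl)c(Cl)c2)[C@H](NC(=O)c2cc(-c3c(Cl)cnn3C)c(Cl)o2)CN1` — 250 nM
compound 3 `Cn1ncc(Cl)c1-c1cc(C(=O)N[C@@H]2CN[C@H](CC(O)CO)C[C@H]2c2ccc(Cl)c(Cl)c2)oc1Cl` — 70 nM

All three share one core and differ only in the side chain on the saturated ring carbon. In a functional assay on LNCaP cells (Homo sapiens) for antiproliferative activity (a higher number here means a weaker inhibitor, a lower number a stronger inhibitor), compound 3 gives the lowest number of the three: it shows a 2.3-fold lower number from compound 1 to compound 3 (0.36 log units; beyond the scatter) and a 3.6-fold lower number from compound 2 to compound 3 (0.55 log units; beyond the scatter), both beyond the scatter, whereas the pair of compound 1 and compound 2 differs only by a 1.6-fold higher number from compound 1 to compound 2 (0.19 log units; within the scatter), within the scatter. The 1,2-dihydroxyethyl side chain therefore stands apart from vinyl and methoxymethyl on these numbers.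

Compound 4 `Cn1ncc(Cl)c1-c1cc(C(=O)N[C@@H]2CN[C@H](CCCO)C[C@H]2c2ccc(Cl)c(Cl)c2)oc1Cl` takes the step hydrogen in place of hydroxy on a saturated chain carbon bound to two saturated chain carbons — read one bond further out, 1,2-dihydroxyethyl becomes 2-hydroxyethyl. Among the measured compounds shown here, no measured pair tests exactly this change. For the measured compounds named here, the steps that bear on it are those into compound 3, which show that adding the two hydroxy groups lowered the number modestly; dropping one of them is expected to give back part of that gain, a modest rise at most. The expected step is a 1.6-fold higher number from compound 3 to compound 4 (0.20 log units; within the scatter). For compound 4 in this assay the estimate is 110 nM, with a range from 55 nM to 250 nM.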

Compound 4, half-maximal inhibitory concentration: 210 nM
Beside the measured number, compound 4's estimate is 1.9-fold (0.28 log units) below it, and the stated range covers the measured number.
By their numbers in this assay, from the lowest: compound 3; then compounds 1, 4 and 2 (each within the scatter of the next).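

In this assay, the separation of compound 3 rests on the single hydroxy on a saturated chain carbon bound to two saturated chain carbons: hydrogen in its place gives a clear loss (a 3.0-fold higher number from compound 3 to compound 4 (0.48 log units; beyond the scatter)). The 2-hydroxyethyl chain that remains does not separate from the other two side chains (a 1.2-fold lower number from compound 2 to compound 4 (0.08 log units; within the scatter); a 1.3-fold higher number from compound 1 to compound 4 (0.12 log units; within the scatter)), so one hydroxy on this chain is not enough to match the 1,2-dihydroxyethyl result, and two are needed among these compounds. No measurement on hand explains this difference.

As far as these compounds go, whether the hydroxy kept at the other chain carbon alone, as in a 2-hydroxypropyl chain, would behave in the same way stays open. Also open, from the compounds shown here alone, is how an amine or a carboxylic acid in place of the hydroxy, or a longer chain carrying two hydroxy groups, would compare with compound 3.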